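The compounds below may be only part of what the source reports. "The series", "measured", "known", "first", "only" and "open" are said of these compounds alone.

Measured so far:
compound 1 `CC(N)CSc1ccccc1Br` — 64800 nM
compound 2 `Cc1cccc(C)c1[Se]CC(C)N` — 2790 nM

Both numbers come from an assay on isolated protein for inhibition of Amine oxidase [flavin-containing] B (Homo sapiens), read by fluorescence and spectrophotometry; on this read-out lower numbers stand for stronger inhibition and higher numbers for weaker inhibition. Compound 1 gives the higher of the two numbers; compound 2 stands at a lower number, and the gap between the two lies beyond the scatter. For the measured compounds named here, the two structures differ in more than one place, so no single step can be drawn between them, and nothing in the pair tells how one change alone would behave.

Compound 3 `CC(N)CSc1ccccc1` is the next compound for this assay. It differs from compound 1 in a single place: hydrogen in place of bromo on an aromatic carbon. Going by the values given here, no step of this kind between measured compounds is available, so the size of the step is uncertain; the expectation is a modest step toward a higher number, close to the edge of the scatter, given as a 1.4-fold higher number from compound 1 to compound 3 (0.14 log units; within the scatter). For compound 3 the estimated value in this assay is 90000 nM, with a range from 25000 nM to 350000 nM.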

Compound 3, half-maximal inhibitory concentration: 57300 nM
Estimate against measurement, compound 3: 1.6-fold (0.20 log units) above; the measured number falls inside the stated range.
By their numbers in this assay, from the lowest: compound 2; then compounds 3 and 1 (each within the scatter of the next).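

In this assay, hydrogen in place of bromo on an aromatic carbon, ortho to a group of 5 heavy atoms, gives a 1.1-fold lower number from compound 1 to compound 3 (0.05 log units; within the scatter). For the compounds shown here, this is the first single-place step, and it shows that at this place on the shared core the bromo group and hydrogen cannot be told apart in this read-out. No supporting data on hand bear on the reason for this result.

Compound 2 differs from compound 3 in more than one place, so its lower number cannot be assigned to any single feature of its structure. As far as these compounds go, whether a methoxy group or a nitrile at this same place would also stay within the scatter of hydrogen remains open, as does the effect of a longer chain in place of the side chain.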